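Cytotoxicity of a shared core with varied amide caps

This account rests on a few compounds, and the source may have more. Where it says the series, first, only, none or still open, it means among the compounds named here.

Compound 1, `Cc1ccc(S(=O)(=O)N[C@@H](CC(=O)NC(C)(C)C)C(=O)NCCNS(=O)(=O)c2ccccc2)cc1`, gives in an ADME assay on HepG2 cells (Homo sapiens) for cytotoxicity (a lower number here means that less compound is needed, a higher number that more compound is needed for the effect), only a limit: > 11000 nM.
Compound 2, `Cc1ccc(S(=O)(=O)N[C@@H](CC(=O)NC(C)(C)C)C(=O)NCCNC(=O)c2cc(Cl)ccc2Cl)cc1`, gives in this assay only a limit: > 11000 nM.
Compound 3, `Cc1ccc(S(=O)(=O)N[C@@H](CC(=O)NC(C)(C)C)C(=O)NCCNC(=O)c2cc(C)ccn2)cc1`, gives in this assay only a limit: > 11000 nM.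

All three measured compounds share one core and differ only in the group that caps the second amine nitrogen. For the measured compounds named here, none of them reached a measurable effect in this assay; each sits at the limit of the assay, as the one piece of evidence shows: the limit of > 11000 nM in this assay, at which 3 of the 3 values shown sit. Because of that, the steps between them cannot be read: a step that the two limits leave unreadable from compound 1 to compound 2, a step that the two limits leave unreadable from compound 1 to compound 3 and a step that the two limits leave unreadable from compound 2 to compound 3 all stay hidden behind the limits, so compound 3 stands exactly where compounds 1 and 2 stand, at the limit.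

Compound 4, `C#Cc1cccc(C(=O)NCCNC(=O)[C@H](CC(=O)NC(C)(C)C)NS(=O)(=O)c2ccc(C)cc2)c1`, is not yet measured. It differs from compound 3 in one place: 3-ethynylphenyl in place of 4-methylpyridin-2-yl on a carbonyl carbon.

Since every measured cap, sulfonyl or carbonyl, aromatic or heteroaromatic, left the compound at the limit of this assay, the change to compound 4 is expected to stay within that picture, with no step beyond the scatter: a step that the limit leaves unreadable from compound 3 to compound 4. Compound 4 is therefore estimated at 15000 nM, in the range 7000 nM to 50000 nM, most likely reported again as a limit.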

Compound 4, half-maximal effective concentration: > 11000 nM
Compound 4: no number, only a limit; the forecaster's own chance of this, stated with the estimate: 85%; the middle value does not contradict the limit.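

Compound 4, like compound 1, compound 2 and compound 3, gives only a limit in this assay, so the steps from each of them to compound 4 cannot be read: the limit of > 11000 nM in this assay, at which 4 of the 4 values shown sit. The compounds shown leave open how much of each would be needed for the effect, and whether the caps on the shared core differ at all in this assay.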